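Halogen swap on the aryl group of compound 2

A few compounds are considered here, and "the series" means these few. Any claim that something is new, unique, unknown or untested is made for them only; others in the source may bear on it.

Values in an ADME assay on Vero cells (Chlorocebus sabaeus) for cytotoxicity, read by neutral red uptake, tested at 787 ug/mL (on this read-out lower numbers stand for a stronger effect and higher numbers for a weaker effect at the one concentration tested), for the three measured members of the series:
compound 1, `O=C1CSC(c2c(Cl)cccc2Cl)N1CCN1CCCCC1`: compound 1 gives 11%
compound 2, `O=C1CSC(c2cccc(Cl)c2)N1CCN1CCCCC1`: compound 2 gives 31%
compound 3, `COc1ccccc1C1SCC(=O)N1CCN1CCCCC1`: compound 3 gives 30%

Compound 2 stands at the highest of the three numbers in this assay, that is, at the weaker end of the effect seen so far. Compound 3 lies nearest to it, and the gap between compound 2 and compound 3 is within the scatter, so the two cannot be ordered. Compound 1 lies furthest from compound 2, with a lower number, and that gap is beyond the scatter.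

The next compound, compound 4, `O=C1CSC(c2cccc(F)c2)N1CCN1CCCCC1`, has not yet been measured. It differs from compound 2 in one place: fluoro in place of chloro on an aromatic carbon. Going by the values given here, no pair of measured compounds carries that same change, so nothing measured here shows what it does to the read-out in this assay.

Among the compounds with values here, with no step of this kind on record, the expectation is a change of about the size of the scatter, estimated as a number 2 percentage points higher from compound 2 to compound 4 (within the scatter). Compound 4 is therefore expected to give about 33% in this assay. The estimated range for compound 4 runs from 15% to 52%.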

Compound 4, a percentage reported as activity, at one concentration (the size of the read-out at that concentration, not a potency): 27%
For compound 4 the middle estimate is 6 percentage points above the measured one, within the range that was stated.
By their numbers in this assay, from the lowest: compound 1; then compounds 4, 3 and 2 (each within the scatter of the next).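

Fluoro in place of chloro on an aromatic carbon, here the change from 3-chlorophenyl to 3-fluorophenyl, gives a number 4 percentage points lower from compound 2 to compound 4 (within the scatter) in this assay, and this is the first measured instance of that change in the series. At this place on the aromatic ring, the two halogens therefore cannot be told apart by this read-out, so this one position tolerates the exchange without a change that can be distinguished from the scatter. Nothing available offers an explanation for this result.

Going by these compounds alone, how a nitrile, an amine or a carboxylic acid on the same aromatic carbon would read remains open, so the single halogen exchange does not show how far this position can move the read-out in this assay. Also open, on these data alone, is whether fluoro in place of chloro would read the same way on a different carbon of the aromatic ring or alongside a second group on that ring.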